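The compounds below may be only part of what the source reports. "The series", "measured", "known", "first", "only" and "open" are said of these compounds alone.

Three measured compounds share one core. Compound 1 `COc1cc(/C=C2\CN(S(=O)(=O)c3ccc(F)cc3)C/C(=C\c3cc(OC)cc(OC)c3)C2=O)cc(OC)c1` gives 19800 nM in an ADME assay on L02 cells (Homo sapiens) for cytotoxicity, read by MTT assay, with a stated time of 24 h; a higher number here means a weaker inhibitor, a lower number a stronger inhibitor. Compound 2 `COc1cc(/C=C2\CN(S(=O)(=O)c3ccc(F)cc3)C/C(=C\c3cc(OC)c(OC)c(OC)c3)C2=O)cc(OC)c1` gives 12300 nM in this assay. The change hydrogen in place of methoxy on an aromatic carbon gives the step of a 1.6-fold higher number from compound 2 to compound 1 (0.21 log units; within the scatter). Compound 3 `COc1cc(/C=C2\CN(S(=O)(=O)c3ccc(NC(C)=O)cc3)C/C(=C\c3ccccc3F)C2=O)cc(OC)c1OC` gives 14000 nM in this assay; the difference between the core of compound 3 and that of compound 2 is not broken down here. Compound 4 `COc1cc(/C=C2\CN(S(=O)(=O)c3ccc(NC(C)=O)cc3)C/C(=C\c3ccccc3F)C2=O)cc(OC)c1` is not yet measured. It differs from compound 3 by hydrogen in place of methoxy on an aromatic carbon, the same change as that from compound 2 to compound 1, with the same surroundings at the place. For compound 4 a step of similar size is expected, a 1.2-fold higher number from compound 3 to compound 4 (0.08 log units; within the scatter), because a 1.6-fold higher number from compound 2 to compound 1 (0.21 log units; within the scatter) stayed within the scatter. Compound 4 is therefore estimated at 17000 nM, with a likely range from 9000 nM to 32000 nM.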

Compound 4, half-maximal inhibitory concentration: 15400 nM
Estimate against measurement, compound 4: 1.1-fold (0.04 log units) above; low and high end bracket the measured number.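

In this assay, the change from 3,4,5-trimethoxyphenyl to 3,5-dimethoxyphenyl gives a 1.1-fold higher number from compound 3 to compound 4 (0.04 log units; within the scatter) on the core carrying the acetamide and the fluorophenyl group. The two steps for this change can be compared directly: the same change on two cores in this assay, a 1.6-fold higher number (0.21 log units; within the scatter) from compound 2 to compound 1 and a 1.1-fold higher number (0.04 log units; within the scatter) from compound 3 to compound 4, 1.5-fold (0.17 log units) apart, within the scatter of two such steps.

The change therefore carries across these two cores without a step beyond the scatter, but neither step shows that removing the methoxy moves the number at all, and two cores set no rule for the whole series.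

Still open, going by these compounds, is whether a hydroxy group, an amine or a longer alkoxy chain at the same place would give a step beyond the scatter. Also open, on these data alone, is whether the change behaves alike on cores with a carboxylic acid on the sulfonyl aryl ring.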